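Leucine to Methionine Swap on a Quinone-Bearing Terpenoid

The compounds below may be only part of what the source reports. "The series", "measured", "known", "first", "only" and "open" are said of these compounds alone.

Compound 1 `CC1=CCC[C@H]2[C@](C)(CC3=CC(=O)C=CC3=O)[C@@H](C)CC[C@]12C` is the parent of this small set. In a functional assay on MDA-MB-453 cells (Homo sapiens) for cytotoxicity, read by MTT assay, with a stated time of 72 h (a lower number here means a stronger inhibitor, a higher number a weaker inhibitor), compound 1 gives 16700 nM. Compound 2 `CC1=CCC[C@H]2[C@](C)(CC3=CC(=O)C=C(N[C@@H](CC(C)C)C(=O)O)C3=O)[C@@H](C)CC[C@]12C` carries a (1-carboxy-3-methylbutyl)amino group in place of hydrogen on a double-bonded ring carbon, and in this assay compound 2 gives 10900 nM. That change produced a 1.5-fold lower number from compound 1 to compound 2 (0.19 log units; within the scatter), so compound 2 holds the lowest of the two numbers, with compound 1 nearest and inside the scatter of it.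

Compound 3 `CSCC[C@H](NC1=CC(=O)C=C(C[C@]2(C)[C@@H](C)CC[C@]3(C)C(C)=CCC[C@@H]23)C1=O)C(=O)O` differs from compound 2 by (methylsulfanyl)methyl in place of isopropyl on a saturated chain carbon, two bonds along the chain from an amine nitrogen and a carbonyl carbon. No measured step swaps one such side chain for another; the only step available, from compound 1 to compound 2, adds the whole amino-acid fragment and stayed within the scatter, so the substituent at this carbon has so far shown little leverage on the number. On that basis the step from compound 2 to compound 3 is expected to be a 1.0-fold higher number from compound 2 to compound 3 (0.00 log units; within the scatter), no change beyond the scatter. Compound 3 is therefore estimated at 11000 nM in this assay, with a range from 4500 nM to 27000 nM.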

Compound 3, half-maximal inhibitory concentration: 25600 nM
Compound 3: middle estimate off by 2.3-fold (0.37 log units), on the low side; low and high end bracket the measured number.
By their numbers in this assay, from the lowest: compounds 2, 1 and 3 (each within the scatter of the next, the first and the last beyond it).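

In this assay, the side chain on this saturated chain carbon proves to have some leverage: (methylsulfanyl)methyl in place of isopropyl gives a 2.3-fold higher number from compound 2 to compound 3 (0.37 log units; beyond the scatter), a modest step but the first in this set to pass beyond the scatter. Measured against the parent, the whole (1-carboxy-3-(methylsulfanyl)propyl)amino group in place of hydrogen on the double-bonded ring carbon gives a 1.5-fold higher number from compound 1 to compound 3 (0.19 log units; within the scatter), which stays within the scatter, so in this set the two side chains separate from each other while neither full fragment separates from hydrogen. Nothing available accounts for the gap between the isobutyl and 2-(methylsulfanyl)ethyl chains.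

The compounds shown cannot say whether the step follows the sulfur atom itself or the change in chain shape, and a straight butyl chain or a 2-methoxyethyl chain on the same carbon would bear on that question. Also open, as far as these compounds go, is what part the carboxylic acid plays, since both fragments carry one, and whether a methyl ester or a primary amide in its place would leave these numbers where they stand.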